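Swapping Chloro for Bromo on Compound 1

The source may report more compounds than this note shows. Statements on the series, on what has been measured and on what is new or still open speak of the compounds shown alone.

Compound 1 `NC1=NC2(CCSCC2)N(OCCCOc2cccc(Cl)c2)C(N)=N1` is the starting point here. For the measured compounds named here, in a functional assay on MDA-MB-231 cells (Homo sapiens) for antiproliferative activity, read by MTT assay, with a stated time of 72 h (a lower number here means a stronger inhibitor, a higher number a weaker inhibitor), compound 1 gives 130 nM as the only number available, so it cannot yet be ranked against any relative. A close neighbour, compound 2 `NC1=NC2(CCOCC2)N(OCCCOc2ccc(Cl)cc2Cl)C(N)=N1`, offers no comparison. For compound 2 the entry reads "not determined" (no result reported) and no result exists.

The next molecule, compound 3 `NC1=NC2(CCSCC2)N(OCCCOc2cccc(Br)c2)C(N)=N1`, keeps the core of compound 1 and differs in a single place: bromo in place of chloro on an aromatic carbon describes the swap. The 3-chlorophenoxy group of compound 1 thus becomes a 3-bromophenoxy group in compound 3.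

Going by the values given here, no pair of measured compounds shows what this swap does, so the expectation rests only on how small the edit is. Starting from compound 1 at 130 nM in this assay the expectation is no step beyond the usual scatter of repeated measurements, in either direction. The estimated step of a 1.1-fold lower number from compound 1 to compound 3 (0.03 log units; within the scatter) is therefore expected to stay small. Compound 3 is expected near 120 nM with 50 nM to 300 nM as the estimated range.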

Compound 3, half-maximal inhibitory concentration: 60 nM
Beside the measured number, compound 3's estimate is 2.0-fold (0.30 log units) above it; measured number inside the range.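

For the compounds shown here, the swap of chloro for bromo on the phenoxy ring gives the first measured step: in this assay it is a 2.2-fold lower number from compound 1 to compound 3 (0.34 log units; beyond the scatter), a modest change but one beyond the usual scatter. Until now, compound 1 stood alone, with nothing to show whether the group at this place mattered; this pair shows that replacing a single halogen atom in the 3-chlorophenoxy group, with the rest of the molecule unchanged, is enough to move the antiproliferative read-out. Nothing available explains why bromo gives the lower number here, so the pair records the size and direction of the change but not its cause.

This single pair cannot show whether the trend would continue to iodo or reverse with fluoro, nor how non-halogen groups such as methyl, methoxy or nitrile would behave at the same place on the ring. Going by these compounds alone, it also leaves open whether the same swap would give a similar step on a different core, such as the one carried by compound 2, which has no result to compare.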